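Swapping a Fluoro-Methoxyphenyl for a Carboxyphenyl: Expected Tolerability

The compounds below may be only part of what the source reports. "The series", "measured", "known", "first", "only" and "open" are said of these compounds alone.

Compound 1 `COc1ccc(-n2c(=O)n(Cc3cc4cc(Cl)ccc4n3CCCC#N)c3cnccc32)c(F)c1` was examined in an ADME assay on HeLa cells (Homo sapiens) for cytotoxicity, read by ATP content, with a stated time of 3 days; a lower number here means that less compound is tolerated, a higher number that more compound is tolerated. In this assay compound 1 gives > 50000 nM, which is a limit of the assay rather than a number. A second compound, compound 2 `O=c1n(Cc2cc3cnccc3n2CCCCO)c2cnccc2n1C1CC1`, was measured in the same way. In this assay compound 2 gives > 100000 nM, again a limit rather than a number. Since both measured values are limits, compound 1 cannot be ranked against compound 2; all that can be said is that neither reached a measurable half-maximal cytotoxic concentration.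

Compound 3 `N#CCCCn1c(Cn2c(=O)n(-c3ccc(C(=O)O)cc3)c3ccncc32)cc2cc(Cl)ccc21` has not yet been measured in this assay. It differs from compound 1 in a single place: 4-carboxyphenyl in place of 2-fluoro-4-methoxyphenyl on an aromatic nitrogen. Among the measured compounds shown here, no step between measured compounds that differ in one place is available here, so the effect of such a swap on tolerability has no direct precedent in these data. The expected step from compound 1 to compound 3 is a step that the limit leaves unreadable from compound 1 to compound 3, that is, none beyond the scatter. Compound 3 is estimated at 60000 nM, with a range from 25000 nM to 150000 nM, and this assay is expected most likely to report a limit again.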

Compound 3, half-maximal cytotoxic concentration: > 50000 nM
Compound 3: only a limit was reported; the forecaster's own chance of this, stated with the estimate: 85%; the middle value lies beyond the limit too.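

Among the compounds shown here, compound 1 and compound 3 both stand at a limit of this assay rather than at a number, and no step between the two can be read. The compounds shown leave open whether 4-carboxyphenyl in place of 2-fluoro-4-methoxyphenyl on an aromatic nitrogen changes the concentration tolerated at all, and in which direction.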